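This account rests on a few compounds, and the source may have more. Where it says the series, first, only, none or still open, it means among the compounds named here.

Measured so far:
- compound 1 `c1cnc(NCCNCC2CCc3ccccc3O2)nc1`: 31.6 nM
- compound 2 `CC1(CNCCCNC2=NCCCN2)CCc2ccccc2O1`: > 1000 nM
- compound 3 `c1ccc2c(c1)CCC(CNCCCNC1=NCCCC1)O2`: 3.98 nM

In an assay on isolated protein (Bos taurus) with 5-hydroxytryptamine receptor 1D (Homo sapiens) as the target (a higher number here means a weaker inhibitor, a lower number a stronger inhibitor), compound 1 gives 31.6 nM. For compound 2 the result is a limit of the assay, > 1000 nM, and not a number, as described by the limit of > 1000 nM in this assay, at which 1 of the 3 values shown sits. Compound 3, with its value of 3.98 nM, stands lowest of the two numbers shown, and the gap to compound 1 lies beyond the scatter of repeated measurements.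

Compound 4 `O=C1CCCN=C(NCCCNCC2CCc3ccccc3O2)N1` has not yet been measured. Its structure differs from compound 3 by a group of 8 heavy atoms (5 carbon, 2 nitrogen, 1 oxygen; one seven-membered non-aromatic ring with 2 hetero atoms) in place of a group of 6 heavy atoms (5 carbon, 1 nitrogen; one six-membered non-aromatic ring with 1 hetero atom), on an amine nitrogen. Going by the values given here, no pair of measured compounds differs in just this way, so the size of the step is uncertain. The expected step from compound 3 to compound 4 in this assay is a 25-fold higher number from compound 3 to compound 4 (1.40 log units; beyond the scatter), towards a higher number. Compound 4 is therefore estimated at 100 nM, within a range from 20 nM to 600 nM.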

Compound 4, half-maximal inhibitory concentration: 158 nM
Estimate against measurement, compound 4: 1.6-fold (0.20 log units) below, and the stated range covers the measured number.
By their numbers in this assay, from the lowest: compound 3; then compound 1; then compound 4. At a limit, above all of these: compound 2.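

In this assay, putting the seven-membered non-aromatic ring with 2 hetero atoms in place of the six-membered non-aromatic ring with 1 hetero atom, on the amine nitrogen, gives a 40-fold higher number from compound 3 to compound 4 (1.60 log units; beyond the scatter). Going by these compounds alone, this is the first pair of compounds here that differ in one place, and it shows that the group on this nitrogen can shift the number strongly, although ring size, hetero atoms and hydrogen-bond donors and acceptors all change together in this one swap. Nothing measured here gives a reason for the step.

As far as these compounds go, it remains open which of these changes carries the step: a seven-membered ring without the carbonyl, or a six-membered ring with one, would separate them. From the compounds shown here alone, how a simple primary amine in this place would compare also remains open.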